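The source may hold more compounds than are shown below. What is called first, only, known or untested is meant among the compounds shown, and "the series" means these compounds.

Compound 1 `Cc1nnsc1CO/N=C/c1c(C)nn(C)c1Oc1ccccc1Cl`: in a functional assay on Huh-7 cells (Homo sapiens) for inhibition, read by MTT assay, with a stated time of 48 h (a lower number here means a stronger inhibitor, a higher number a weaker inhibitor), compound 1 gives > 50000 nM, a limit of the assay.
Compound 2 `Cc1nnsc1CO/N=C/c1c(C)nn(C)c1Oc1cccc(F)c1`: in this assay compound 2 gives > 50000 nM, again a limit.
Compound 3 `Cc1ccc(Oc2c(/C=N/OCc3snnc3C)c(C)nn2C)cc1`: in this assay compound 3 gives > 50000 nM, once more a limit.

Compound 3 thus stands at the limit of the assay, not at a number; all three values shown sit there, as the limit of > 50000 nM in this assay, at which 3 of the 3 values shown sit, records. The steps among the measured compounds, a step that the two limits leave unreadable from compound 1 to compound 2, a step that the two limits leave unreadable from compound 1 to compound 3 and a step that the two limits leave unreadable from compound 2 to compound 3, are unreadable, both ends of each lying at the limit.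

Compound 4 `Cc1nnsc1CO/N=C/c1c(C)nn(C)c1Oc1cccc(F)c1F` differs from compound 3 by 2,3-difluorophenyl in place of 4-methylphenyl on an oxygen on an aromatic ring. The three measured steps each exchanged one aryl group on the same oxygen and none moved the value off the limit, so they give no readable step in either direction, and the change to compound 4 is of the same kind. No step beyond the scatter is therefore expected in this assay from compound 3 to compound 4, and the expected step of a number no higher from compound 3 to compound 4 (the limit leaves the size open) rests only on that. The estimate for compound 4 in this assay is 50000 nM, within a range of 20000 nM to 150000 nM, most likely again reported only as a limit.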

Compound 4, half-maximal inhibitory concentration: 10200 nM
For compound 4 the middle estimate is 4.9-fold (0.69 log units) above the measured one, and the stated range ends above it.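

The group on this oxygen can move the value in this assay off the limit, which the three earlier aryl exchanges did not do. Exchanging 4-methylphenyl for 2,3-difluorophenyl gives an at least 4.9-fold lower number from compound 3 to compound 4 (0.69 log units; beyond the scatter), and the same aryl group in place of 2-chlorophenyl gives an at least 4.9-fold lower number from compound 1 to compound 4 (0.69 log units; beyond the scatter), while the smallest of the changes, fluoro in place of hydrogen on an aromatic carbon, gives an at least 4.9-fold lower number from compound 2 to compound 4 (0.69 log units; beyond the scatter). That single added fluoro thus separates a compound at the limit from compound 4, the only compound of the four with a number, but the size of each step stays open at one end: the limit of > 50000 nM in this assay, at which 3 of the 4 values shown sit.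

The compounds shown leave open how other groups on the same oxygen would fare, such as 2,3-dichlorophenyl or a phenyl ring carrying an amine or a carboxylic acid, and so whether the step belongs to fluoro in particular. They also leave open how much the rest of the shared core contributes to the value of compound 4, since that part is the same in all four compounds.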